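Changing the Aryl Group on the Ring Amine Nitrogen

This account rests on a few compounds, and the source may have more. Where it says the series, first, only, none or still open, it means among the compounds named here.

Of the compounds shown here, three sharing one core have been tested in a functional assay on HL-60 cells (Homo sapiens) for inhibition, read by MTT assay, with a stated time of 72 h; a higher number here means a weaker inhibitor, a lower number a stronger inhibitor. Compound 1 `Cc1ccc(C)c(N2CCN(C(=O)c3oc(C)nc3-c3ccc(Cl)cc3)CC2)c1` gives "not active" (no number reported), so no number was reported for it. Compound 2 `Cc1ccc(C)c(N2CCN(C(=O)c3oc(C)nc3-c3ccc(F)cc3)CC2)c1` gives 358 nM, and compound 3 `Cc1ccc(C)c(N2CCN(C(=O)c3oc(C)nc3-c3cccc(F)c3)CC2)c1` gives 204 nM. Among the two numbers, compound 2 has the higher one, but the only single-change step, a 1.8-fold lower number from compound 2 to compound 3 (0.24 log units; within the scatter), lies within the scatter, so the two compounds cannot be told apart on these data.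

Compound 4 `Cc1nc(-c2ccc(F)cc2)c(C(=O)N2CCN(c3cc(Cl)cc(Cl)c3)CC2)o1` has not yet been measured in this assay. Relative to compound 2, the change is 3,5-dichlorophenyl in place of 2,5-dimethylphenyl on an amine nitrogen in a ring. The group on the amine nitrogen in the six-membered non-aromatic ring with 2 nitrogen is thus exchanged while everything else stays the same.

Among the compounds with values here, no measured step touches this position; the one step known concerns the fluorophenyl ring instead and was within the scatter. There is therefore no basis for expecting a shift in either direction, only a wide uncertainty. Compound 4 is expected to give 400 nM, with a range from 120 nM to 1500 nM. This estimate means a step of a 1.1-fold higher number from compound 2 to compound 4 (0.05 log units; within the scatter), expected to stay within the scatter.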

Compound 4, half-maximal inhibitory concentration: 52.1 nM
Compound 4: middle estimate off by 7.7-fold (0.89 log units), on the high side; the measured number lies below the stated range.
By their numbers in this assay, from the lowest: compound 4; then compounds 3 and 2 (each within the scatter of the next).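

Within the data shown here, the group on the amine nitrogen in the ring clearly counts in this assay: exchanging 2,5-dimethylphenyl for 3,5-dichlorophenyl gives a 6.9-fold lower number from compound 2 to compound 4 (0.84 log units; beyond the scatter), so this position can move the number by more than the usual scatter, which the only earlier step, on the fluorophenyl ring, did not do. The change is also a narrow one by simple counts, since both groups have the same number of heavy atoms, a single six-membered aromatic ring of carbon only, no hydrogen-bond donors or acceptors and no net charge, and they differ in carrying two chlorine atoms rather than two methyl groups and in where these stand on the ring. Nothing available here explains why the number falls at this position, and no measurement of any property of these groups bears on the result.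

This single step changes the kind of substituent and its place on the ring together, so the two contributions cannot be separated. A 3,5-dimethylphenyl or a 2,5-dichlorophenyl group on the same nitrogen would pull them apart, and an unsubstituted phenyl group would show what the substituents add at all.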